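Salicylamide anilides: isopropyl branching on the linker carbon

The source may hold more compounds than are shown below. What is called first, only, known or untested is meant among the compounds shown, and "the series" means these compounds.

Compound 2 `O=C(CNC(=O)c1cc(Cl)ccc1O)Nc1ccc(Cl)c(Cl)c1` has been run in a functional assay on MCF7 cells (Homo sapiens) for cytotoxicity, with a stated time of 72 h; a lower number here means a stronger inhibitor, a higher number a weaker inhibitor. For compound 2 the reading is a limit of the assay and not a number, > 20000 nM; it sits at the limit of > 20000 nM in this assay, at which 1 of the 2 values shown sits. Compound 1 `CC(C)[C@H](NC(=O)c1ccc(Cl)cc1O)C(=O)Nc1ccc(Cl)c(Cl)c1`, which carries the isopropyl group but with the chlorine placed elsewhere on the same ring, also gives only a limit in this assay, > 10000 nM; it sits at the limit of > 10000 nM in this assay, at which 1 of the 2 values shown sits. Of the two compounds nothing more can be said than that neither yields a measurable number, so compound 2 cannot be ordered against compound 1. Compound 3 `CC(C)[C@H](NC(=O)c1cc(Cl)ccc1O)C(=O)Nc1ccc(Cl)c(Cl)c1` is not yet measured. It differs from compound 2 by isopropyl in place of hydrogen on a saturated chain carbon bound to an amide-type nitrogen and a carbonyl carbon. Among the compounds with values here, no measured pair covers this change. The expected step of a number no higher from compound 2 to compound 3 (the limit leaves the size open) is none beyond the scatter, with compound 3 expected to be reported again as a limit. The estimate for compound 3 in this assay is 20000 nM, within 5000 nM to 80000 nM.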

Compound 3, half-maximal inhibitory concentration: > 10000 nM
Compound 3: only a limit was reported (the forecaster's own chance of this, stated with the estimate: 75%); the middle value lies beyond the limit too.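

In this assay compound 3 gives only a limit of the assay, > 10000 nM, so its steps from compound 1 and compound 2 cannot be read. Open, from the compounds shown here alone, is whether isopropyl in place of hydrogen, or 5-chloro-2-hydroxyphenyl in place of 4-chloro-2-hydroxyphenyl, changes the read-out at all.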